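Working notes: acetoxy to 2-hydroxyethyl on compound 3

This account rests on a few compounds, and the source may have more. Where it says the series, first, only, none or still open, it means among the compounds named here.

Measured in a physicochemical assay for acid dissociation
- compound 1 `NS(=O)(=O)c1ccc(SCCCO)c(Cl)c1` gives 9.45
- compound 2 `NS(=O)(=O)c1ccc(SCCCCO)s1` gives 9.5
- compound 3 `CC(=O)OCCCc1ccc(S(N)(=O)=O)cc1` gives 10.2

Compound 3 stands highest of the three, and its gaps to compound 1 and compound 2 both lie beyond the scatter. Compound 4 `NS(=O)(=O)c1ccc(CCCCCO)cc1` carries 2-hydroxyethyl in place of acetoxy on a saturated chain carbon, three bonds along the chain from an aromatic carbon. For the measured compounds named here, no measured pair shows this change, and compound 3 at 10.2 is the closest measured structure. The expected step in this assay is none beyond the scatter, an estimated no change at the digits printed from compound 3 to compound 4 (within the scatter) in either direction. The expected value for compound 4 is 10.2 (estimated range 9.9 to 10.5).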

Compound 4, acid dissociation constant: 10.3
Compound 4: middle estimate off by 0.10 log units, on the low side; low and high end bracket the measured number.
By their numbers in this assay, from the lowest: compounds 1 and 2 (each within the scatter of the next); then compounds 3 and 4 (each within the scatter of the next).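

In this assay, for the compounds shown here, 2-hydroxyethyl in place of acetoxy on a saturated chain carbon, three bonds along the chain from an aromatic carbon, gives a number 0.10 log units higher from compound 3 to compound 4 (within the scatter) and is the first single-place step. At this place, going from a group with no hydrogen-bond donor to one with a hydrogen-bond donor leaves the read-out within the scatter, so compound 3 and compound 4 cannot be told apart here. Going by these compounds, whether an amine or a carboxylic acid at this place would also stay within the scatter remains open. No measured property accounts for this step.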